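Dechlorination of the dithiocarbamate chromone series

The source may hold more compounds than are shown below. What is called first, only, known or untested is meant among the compounds shown, and "the series" means these compounds.

Measured so far:
compound 1 `O=c1c(CSC(=S)N2CCOCC2)coc2cc(Cl)ccc12` — 6200 nM
compound 2 `O=c1c(CSC(=S)N2CCCC2)coc2cc(Cl)ccc12` — 2600 nM

Within the data shown here, in a functional assay on LM7 cells (Homo sapiens) for antiproliferative activity, read by MTT assay, with a stated time of 72 h (on this read-out lower numbers stand for stronger inhibition and higher numbers for weaker inhibition), compound 2 holds the lowest of the two numbers; its nearest neighbour is compound 1, separated by the step of a 2.4-fold lower number from compound 1 to compound 2 (0.38 log units; beyond the scatter), the only change so far recorded, and it concerns the amine on the thiocarbonyl carbon, not the aromatic ring.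

Compound 3 `O=c1c(CSC(=S)N2CCCC2)coc2ccccc12` is the next analogue: hydrogen in place of chloro on an aromatic carbon. Among the measured compounds shown here, no measured step touches this position, so the one recorded step gives no direct guide; the chloro substituent's contribution is simply unknown within this set. With nothing to anchor a direction, compound 3 is expected to sit close to compound 2, with at most a modest drift toward higher numbers in this assay, so the step of a 1.3-fold higher number from compound 2 to compound 3 (0.13 log units; within the scatter) is estimated to stay near the scatter. The estimate for compound 3 in this assay is 3500 nM, ranging from 1200 nM to 10000 nM.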

Compound 3, half-maximal inhibitory concentration: 6000 nM
Compound 3: the middle estimate sits 1.7-fold (0.23 log units) below what was measured, and the stated range covers the measured number.
By their numbers in this assay, from the lowest: compound 2; then compounds 3 and 1 (each within the scatter of the next).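

In this assay, a 2.3-fold higher number from compound 2 to compound 3 (0.36 log units; beyond the scatter) shows that this aromatic carbon matters to the read-out: with pyrrolidin-1-yl held constant, the chloro compound gives the lower number. The aromatic ring is therefore a second place where a single change moves the number beyond the scatter, alongside the amine on the thiocarbonyl carbon, where the step is a 2.4-fold lower number from compound 1 to compound 2 (0.38 log units; beyond the scatter). No supporting measurement is available to explain the effect of losing the chloro.

As far as these compounds go, each of the two places has so far been read only once, so it remains open whether the chloro step carries over to the morpholin-4-yl series. From the compounds shown here alone, it is also open how fluoro, bromo, methoxy or an amine on this aromatic carbon would compare with chloro and hydrogen.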